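Chalcone-Type Quinolines: Fluoro to Hydroxy on the Aryl Ketone

A few compounds are considered here, and "the series" means these few. Any claim that something is new, unique, unknown or untested is made for them only; others in the source may bear on it.

Measured compounds:
compound 1 `COc1ccc(-c2cc3ccccc3nc2/C=C/C(=O)c2ccccc2)cc1` — 860 nM
compound 2 `COc1ccc(-c2cc3ccccc3nc2/C=C/C(=O)c2ccc(F)cc2)cc1` — 830 nM

Of the compounds shown here, two sharing the same core have been tested in a functional assay on MDA-MB-231 cells (Homo sapiens) for antiproliferative activity, read by XTT assay, with a stated time of 72 h; a lower number here means a stronger inhibitor, a higher number a weaker inhibitor. Compound 1 gives 860 nM, and compound 2 gives 830 nM. Among the compounds with values here, the only measured step, a 1.0-fold lower number from compound 1 to compound 2 (0.02 log units; within the scatter), lies within the scatter, so on these numbers compound 2 and compound 1 cannot be told apart, and compound 2 simply stands with the lower of the two figures.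

Compound 3 `COc1ccc(-c2cc3ccccc3nc2/C=C/C(=O)c2ccc(O)cc2)cc1` is not yet measured. It differs from compound 2 by hydroxy in place of fluoro on an aromatic carbon. Within the data shown here, the single measured step bears on it only indirectly: exchanging hydrogen for fluoro at this same place, from compound 1 to compound 2, left the result unchanged within the scatter. Among the measured compounds shown here, no measured step involves a hydroxy group at this position, so there is no direct precedent for the size of this change. With only the small step of a 1.0-fold lower number from compound 1 to compound 2 (0.02 log units; within the scatter) to go on, a step of no more than the scatter is expected in this assay, in either direction, and compound 3 is therefore estimated at 800 nM (range 300 nM to 2500 nM), corresponding to an expected step of a 1.0-fold lower number from compound 2 to compound 3 (0.02 log units; within the scatter).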

Compound 3, half-maximal inhibitory concentration: 6350 nM
Estimate against measurement, compound 3: 7.9-fold (0.90 log units) below; the measured number lies above the stated range.
By their numbers in this assay, from the lowest: compounds 2 and 1 (each within the scatter of the next); then compound 3.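

In this assay, this position proves sensitive to what it carries: hydroxy in place of fluoro gives a 7.7-fold higher number from compound 2 to compound 3 (0.88 log units; beyond the scatter), and hydroxy in place of hydrogen gives a 7.4-fold higher number from compound 1 to compound 3 (0.87 log units; beyond the scatter). The flat step seen earlier with fluoro therefore described that one group and not the position as a whole, and compound 3 stands as the weakest of the three, with both of its steps beyond the scatter. No evidence at hand accounts for this difference.

As far as these compounds go, it remains open whether the weaker result belongs to the hydroxy group alone or would also appear with a methoxy group, an amine or a carboxylic acid on the same aromatic carbon, which would show how narrowly the change is tied to hydroxy. From the compounds shown here alone, it is also open whether hydroxy on another carbon of the same ring would give a step of similar size, or whether the effect is confined to this one place on the 4-hydroxyphenyl group.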